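Amide side chain swap on the shared core

The source may report more compounds than this note shows. Statements on the series, on what has been measured and on what is new or still open speak of the compounds shown alone.

Measured in a functional assay on EBC-1 cells (Homo sapiens) for antiproliferative activity, with a stated time of 72 h; a higher number here means a weaker inhibitor, a lower number a stronger inhibitor:
- compound 1 `COc1ccc(-c2cc(F)c3ncc(Cc4ccc5ncccc5c4)n3c2)cc1F` gives 407 nM
- compound 2 `O=C(NC1CCCNC1)c1ccc(-c2cc(F)c3ncc(Cc4ccc5ncccc5c4)n3c2)cc1F` gives 138 nM
- compound 3 `O=C(NCc1ccccn1)c1ccc(-c2cc(F)c3ncc(Cc4ccc5ncccc5c4)n3c2)cc1F` gives 5550 nM

Compound 3 holds the highest number of the three, with a 14-fold higher number from compound 1 to compound 3 (1.13 log units; beyond the scatter). The next compound is compound 4 `O=C(NCc1cc(F)cc(F)c1)c1ccc(-c2cc(F)c3ncc(Cc4ccc5ncccc5c4)n3c2)cc1F`, with 3,5-difluorophenyl in place of pyridin-2-yl on a saturated chain carbon bound to an amide-type nitrogen. The closest measured change, on the amide-type nitrogen, is large: a 40-fold higher number from compound 2 to compound 3 (1.60 log units; beyond the scatter). The step of a 2.9-fold lower number from compound 1 to compound 2 (0.47 log units; beyond the scatter) is modest by comparison. For the measured compounds named here, no measured pair compares pyridin-2-yl with a carbon-only ring, so the direction is uncertain, but a modest step to a lower number is expected. Compound 4 is estimated at 3000 nM, with an expected range of 800 nM to 10000 nM. This estimate means a 1.9-fold lower number from compound 3 to compound 4 (0.27 log units; within the scatter).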

Compound 4, half-maximal inhibitory concentration: 53.6 nM
Estimate against measurement, compound 4: 56-fold (1.75 log units) above; measured number outside the range, below it.
By their numbers in this assay, from the lowest: compound 4; then compound 2; then compound 1; then compound 3.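

In this assay, the aromatic ring on the saturated chain carbon bound to an amide-type nitrogen has a large influence on the number, with 3,5-difluorophenyl in place of pyridin-2-yl (a 100-fold lower number from compound 3 to compound 4 (2.02 log units; beyond the scatter)). The carbamoyl replacement for methoxy can therefore also lower the number (a 7.6-fold lower number from compound 1 to compound 4 (0.88 log units; beyond the scatter)), and piperidin-3-yl is not the only amide substituent that does so (a 2.6-fold lower number from compound 2 to compound 4 (0.41 log units; beyond the scatter)). No evidence on the cause of these steps is available.

Still open, going by these compounds, is whether the ring carbon in place of nitrogen or the fluorines drive the step, which unsubstituted benzyl would help separate. Also open, on these data alone, is how a longer chain, such as phenethyl, would compare.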